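A Chlorine Added to One Phenyl Ring of Compound 1

The source may hold more compounds than are shown below. What is called first, only, known or untested is meant among the compounds shown, and "the series" means these compounds.

For the measured compounds named here, compound 1 `CCOC(=O)C1=C(C)NC(c2ccccc2)=CC1c1ccccc1` is one of two compounds measured in an assay on SH-SY5Y cells for inhibition of Voltage-dependent L-type calcium channel subunit alpha-1D (Homo sapiens), read by calcium flux, with a stated time of 15 min (on this read-out lower numbers stand for stronger inhibition and higher numbers for weaker inhibition), where compound 1 gives 18700 nM. The other, compound 2 `CC(=O)C1=C(C)NC(c2ccccc2)=CC1c1ccccc1`, gives 27100 nM in this assay. Going by the values given here, the only measured step, a 1.4-fold higher number from compound 1 to compound 2 (0.16 log units; within the scatter), concerns a change on a carbonyl carbon and lies within the scatter, so the two numbers sit close together and neither can be called stronger. Compound 3 `CCOC(=O)C1=C(C)NC(c2ccc(Cl)cc2)=CC1c1ccccc1` differs from compound 1 by chloro in place of hydrogen on an aromatic carbon. Among the compounds with values here, no measured step touches this ring, so the single measured step offers no guide to the size or direction of the change, and nothing beyond the scatter is expected. Compound 3 is therefore estimated at 15000 nM in this assay, with a range from 6000 nM to 40000 nM. That estimate means an expected step of a 1.2-fold lower number from compound 1 to compound 3 (0.10 log units; within the scatter).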

Compound 3, half-maximal inhibitory concentration: 9300 nM
Compound 3: the middle estimate sits 1.6-fold (0.21 log units) above what was measured; the measured number falls inside the stated range.
By their numbers in this assay, from the lowest: compounds 3, 1 and 2 (each within the scatter of the next, the first and the last beyond it).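

For the compounds shown here, this is the first measured change on this phenyl ring, a part of the molecule that the earlier step at the carbonyl carbon did not touch. Going from phenyl to 4-chlorophenyl gives a 2.0-fold lower number from compound 1 to compound 3 (0.30 log units; within the scatter) in this assay and so shows that chloro can stand in place of hydrogen here, para to a large group, without taking the number beyond the usual scatter. The two compounds therefore cannot be ranked against each other.

Still open, on these data alone, is whether a different group at this place, such as a methoxy group or an amine, would move the number beyond the scatter. Also open, as far as these compounds go, is whether chloro on the other phenyl ring would do so. No evidence is available that bears on this result.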